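Benzyl at the saturated ring carbon of compound 2

The compounds below may be only part of what the source reports. "The series", "measured", "known", "first", "only" and "open" are said of these compounds alone.

Measured values in an assay on Sf9 cells for inhibition of serine/threonine-protein kinase 4 (Homo sapiens), read by luminescence and ADP-Glo, with a stated time of 1 h, in the presence of a further agent that is not named here; a lower number here means a stronger inhibitor, a higher number a weaker inhibitor:
compound 1 `CN1CC(=O)N(C)c2cnc(Nc3ccc(S(N)(=O)=O)cc3)nc21` gives 495 nM
compound 2 `CC1C(=O)N(C)c2cnc(Nc3ccc(S(N)(=O)=O)cc3)nc2N1C` gives 313 nM
compound 3 `CN1C(=O)C(c2ccccc2)N(C)c2nc(Nc3ccc(S(N)(=O)=O)cc3)ncc21` gives 383 nM

Compound 2 carries the lowest of the three numbers, yet it is not separated from the others: the step of a 1.6-fold lower number from compound 1 to compound 2 (0.20 log units; within the scatter) and the step of a 1.2-fold higher number from compound 2 to compound 3 (0.09 log units; within the scatter) both lie within the scatter, as does a 1.3-fold lower number from compound 1 to compound 3 (0.11 log units; within the scatter). On the numbers shown, the three compounds cannot be placed in any order.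

Compound 4 `CN1C(=O)C(Cc2ccccc2)N(C)c2nc(Nc3ccc(S(N)(=O)=O)cc3)ncc21` differs from compound 2 by phenyl in place of hydrogen on a saturated chain carbon bound to a saturated ring carbon. Among the compounds with values here, the steps that bear on it are those at the saturated ring carbon: hydrogen to methyl, hydrogen to phenyl and methyl to phenyl, all within the scatter. Nothing in the series shows that a group at this position moves the number either way, so no step beyond the scatter is expected for compound 4, and the expected step is a 1.1-fold higher number from compound 2 to compound 4 (0.02 log units; within the scatter). Compound 4 is therefore estimated at 330 nM in this assay, with an expected range from 160 nM to 700 nM.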

Compound 4, half-maximal inhibitory concentration: > 10000 nM
Compound 4 ended at the assay's limit (the forecaster's own chance of this, stated with the estimate: 3%); middle value at least 30-fold (1.48 log units) from the limit.
By their numbers in this assay, from the lowest: compounds 2, 3 and 1 (each within the scatter of the next). At a limit, above all of these: compound 4.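

In this assay compound 4 stands at a limit of the assay, not at a number: the limit of > 10000 nM in this assay, at which 1 of the 4 values shown sits.

The saturated ring carbon is therefore not indifferent to what it carries: methyl and phenyl there left all steps within the scatter, whereas benzyl in place of hydrogen gives an at least 20-fold higher number from compound 1 to compound 4 (1.30 log units; beyond the scatter), and phenyl on the saturated chain carbon bound to that ring carbon gives an at least 31-fold higher number from compound 2 to compound 4 (1.50 log units; beyond the scatter). Benzyl in place of phenyl gives an at least 26-fold higher number from compound 3 to compound 4 (1.41 log units; beyond the scatter), so a phenyl ring at this carbon is tolerated in compound 3 and the large step appears only with benzyl.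

The compounds shown leave open whether the large step belongs to benzyl alone or also comes with an ethyl or a longer chain. They also leave open what an amine or a carboxylic acid on that chain carbon would do.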